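Two methoxy groups added to a bromoacrylamide lead

A few compounds are considered here, and "the series" means these few. Any claim that something is new, unique, unknown or untested is made for them only; others in the source may bear on it.

Compound 1 `C=C(Br)C(=O)Nc1cccc(-c2cn3nc(-c4ccccc4)sc3n2)c1` was tested in a functional assay on CCRF-CEM cells (Homo sapiens) for inhibition, read by cell counting, with a stated time of 3 days (a lower number here means a stronger inhibitor, a higher number a weaker inhibitor), where compound 1 gives 960 nM, the lowest of the two numbers measured. Compound 3 `COc1ccc(-c2csc3nc(-c4cccc(N)c4)cn23)cc1` gives 6100 nM in the same test. Compound 2 `COc1ccc(Cc2nn3cc(-c4cccc(N)c4)nc3s2)cc1` reaches only a limit of the assay, >= 250000 nM, so no number is known for it; (the limit of >= 250000 nM in this assay, at which 1 of the 3 values shown sits). Compound 4 `C=C(Br)C(=O)Nc1cccc(-c2cn3nc(-c4ccc(OC)c(OC)c4)sc3n2)c1` has not yet been measured. It differs from compound 1 by 3,4-dimethoxyphenyl in place of phenyl on an aromatic carbon. No measured step of this kind is available among these compounds, so the expectation rests on compound 1 alone: the step from compound 1 to compound 4 is expected to be a 1.3-fold higher number from compound 1 to compound 4 (0.10 log units; within the scatter), hardly beyond the scatter. Compound 4 is therefore estimated at 1200 nM, within the range 400 nM to 4000 nM.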

Compound 4, half-maximal inhibitory concentration: 380 nM
Estimate against measurement, compound 4: 3.2-fold (0.50 log units) above; the whole stated range lies above it.
By their numbers in this assay, from the lowest: compound 4; then compound 1; then compound 3. At a limit, above all of these: compound 2.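

In this assay, putting 3,4-dimethoxyphenyl in place of phenyl gives a 2.5-fold lower number from compound 1 to compound 4 (0.40 log units; beyond the scatter). Within the data shown here, this is the first single change that can be read here, and it shows that this aromatic carbon, next to the ring sulfur, tolerates a bigger ring substituent carrying two methoxy groups, with a gain rather than a loss. The values shown offer nothing that explains this gain. As far as these compounds go, whether a single methoxy group would be enough remains open, as does the effect of an amine or a carboxylic acid on this phenyl ring.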